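Pentyl on compound 3: expected cytotoxicity

The source may report more compounds than this note shows. Statements on the series, on what has been measured and on what is new or still open speak of the compounds shown alone.

Measured in a functional assay on HEL cells (Homo sapiens); a lower number here means that less compound is tolerated, a higher number that more compound is tolerated:
- compound 1 `CCCCCCCCCCCc1cc2cn(COCCO)c(O)nc-2n1`: 41000 nM
- compound 2 `CCCCc1cc2cn(COCCO)c(O)nc-2n1`: > 200000 nM (a limit)
- compound 3 `OCCOCn1cc2ccnc-2nc1O`: > 200000 nM (a limit)

Compound 3 stands at a limit and has no number. The same limit holds for compound 2, as the limit of > 200000 nM in this assay, at which 2 of the 3 values shown sit, records. Compound 4 `CCCCCc1cc2cn(COCCO)c(O)nc-2n1` carries pentyl in place of hydrogen on an aromatic carbon. Among the compounds with values here, two measured steps bear on this. The step that the two limits leave unreadable from compound 2 to compound 3 gives no size. The only readable one is an at least 4.8-fold higher number from compound 1 to compound 2 (0.68 log units; beyond the scatter), and it involves removing heptyl from a much longer chain than pentyl. Little change is therefore expected, and any change should be towards a lower number. The expected step is an at least 1.3-fold lower number from compound 3 to compound 4 (0.12 log units; that floor lies within the scatter). Compound 4 is estimated at 150000 nM, with an expected range of 80000 nM to 250000 nM.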

Compound 4, half-maximal cytotoxic concentration: > 200000 nM
Compound 4 ended at the assay's limit; the forecaster's own chance of this, stated with the estimate: 65%; middle value at least 1.3-fold (0.12 log units) away from the limit.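

In this assay compound 4 gives > 200000 nM, which is a limit. Pentyl on this aromatic carbon next to the ring nitrogen adds a second chain length at the limit, and the series gains a further readable step, an at least 4.8-fold higher number from compound 1 to compound 4 (0.68 log units; beyond the scatter). The steps among compound 2, compound 3 and compound 4 cannot be read, as all three share one limit: the limit of > 200000 nM in this assay, at which 3 of the 4 values shown sit.

Still open, on these data alone, is how long the chain must be before a number appears, for instance with an octyl chain. Also open, as far as these compounds go, is how an amine or a carboxylic acid at the chain end would read.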